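From hydroxy to fluoro on a shared core

A few compounds are considered here, and "the series" means these few. Any claim that something is new, unique, unknown or untested is made for them only; others in the source may bear on it.

Of the compounds shown here, two have been tested so far for their effect on lung-derived cells. In a functional assay on A549 cells (Homo sapiens) for cytotoxicity (a lower number here means that less compound is needed, a higher number that more compound is needed for the effect), compound 1 `Oc1cc(-c2ccccc2)nc2cc(F)ccc12`, which carries a fluoro group on the shared core, gives 0.96 ug/mL.

For compound 2 `Oc1cc(-c2ccccc2)nc2c(O)cccc12`, the result in this assay is > 10 ug/mL, which is a limit of the assay and not a number.

Compound 3 `Oc1cc(-c2ccccc2)nc2c(F)cccc12` has not yet been measured. It differs from compound 2 by a single swap, fluoro in place of hydroxy on an aromatic carbon.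

Going by the values given here, no measured pair shows this exact change, so its size can only be judged indirectly. Compound 1, at 0.96 ug/mL, shows that a fluoro-bearing member of this small set can give a clear number in this assay. Its fluoro group sits on a different carbon, however, so the comparison is loose. The expectation is therefore a real step towards less compound being needed, beyond the usual scatter.

The estimated change is an at least 5.0-fold lower number from compound 2 to compound 3 (0.69 log units; beyond the scatter).

For compound 3, the expected value is 2 ug/mL, with an estimated range from 0.5 ug/mL to 9 ug/mL.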

Compound 3, half-maximal effective concentration: 0.61 ug/mL
Compound 3: the middle estimate sits 3.3-fold (0.52 log units) above what was measured; measured number inside the range.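

With compound 3, the swap finally appears as a direct pair: placing fluoro instead of hydroxy on this aromatic carbon, ortho to a fused ring, gives an at least 16-fold lower number from compound 2 to compound 3 (1.21 log units; beyond the scatter) in this assay. Going by these compounds alone, until now the only hint came from compound 1, whose fluoro group sits on a different carbon, whereas here both groups occupy the same carbon and everything else in the structure stays the same, which shows that the result at this place on the shared core is sensitive to this single change. Compound 2 stands at a limit of the assay, so the step gives only a minimum size and not an exact one: the limit of > 10 ug/mL in this assay, at which 1 of the 3 values shown sits.

The compounds shown leave open whether the step depends on fluoro itself or simply on the loss of hydroxy, a question that a plain hydrogen, a chlorine, a methoxy group or an amine on the same carbon would help to answer. They also do not tell whether the same swap would give a step of similar size on other carbons of the shared core.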